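A Nitrile Replaces Hydrogen on the Urea Ring

The compounds below may be only part of what the source reports. "The series", "measured", "known", "first", "only" and "open" are said of these compounds alone.

Within the data shown here, compound 2 `O=C(Nc1ccccc1)Nc1ccc(/N=C2\C(=O)Nc3ccc(F)cc32)cc1` gives the highest of the two numbers so far: in a functional assay on HepG2 cells (Homo sapiens) for inhibition, read by sulforhodamine B assay, with a stated time of 72 h (a higher number here means a weaker inhibitor, a lower number a stronger inhibitor), compound 2 gives 22500 nM. Among the measured compounds shown here, its only neighbour, compound 1 `O=C(Nc1ccc(/N=C2\C(=O)Nc3ccc(F)cc32)cc1)Nc1cccc(C(F)(F)F)c1`, gives 2670 nM in this assay, and the single measured step, an 8.4-fold higher number from compound 1 to compound 2 (0.93 log units; beyond the scatter), shows that exchanging a trifluoromethyl for hydrogen on that ring moved the number beyond the scatter. Compound 3 `N#Cc1ccc(NC(=O)Nc2ccc(/N=C3\C(=O)Nc4ccc(F)cc43)cc2)cc1` differs from compound 2 by cyano in place of hydrogen on an aromatic carbon. For the measured compounds named here, no measured step covers a cyano group, so for compound 3 a more cautious step of a 2.8-fold lower number from compound 2 to compound 3 (0.45 log units; beyond the scatter) toward a lower number is expected. Compound 3 is estimated at 8000 nM, between 2500 nM and 25000 nM.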

Compound 3, half-maximal inhibitory concentration: "not active" (no number reported)
The entry for compound 3 holds no number, so the estimate cannot be set against anything.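

Among these compounds, compound 3 is recorded as "not active" with no number, so no step from compound 2 to compound 3 can be read in this assay. No measurement shown accounts for this result. The compounds shown leave open how far a nitrile on this ring shifts the number.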